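A few compounds are considered here, and "the series" means these few. Any claim that something is new, unique, unknown or untested is made for them only; others in the source may bear on it.

Within the data shown here, compound 2 `CN(CCCc1ccccc1)Cc1cn(C2CCCCC2OC(=O)COc2ccccc2)nn1` stands highest of the two numbers measured so far: in an assay on nucleic acid for inhibition of Nucleic Acid, read by fluorescence, tested at 100 uM (on this read-out lower numbers stand for less inhibition and higher numbers for more inhibition at the one concentration tested (going by the name of the read-out)), compound 2 gives 42%, while compound 1 `CN(CCCc1ccccc1)Cc1cn(CC(O)COCc2ccccc2)nn1` gives 18%, a gap beyond the usual scatter. Among the measured compounds shown here, no step between these two measured compounds has been worked out. Compound 3 `CC(C)CCN(C)Cc1cn(C2CCCCC2OC(=O)COc2ccccc2)nn1` differs from compound 2 by isopropyl in place of benzyl on a saturated chain carbon, two bonds along the chain from an amine nitrogen. For the measured compounds named here, with no measured step to lean on, a modest fall in this assay is expected, close to the edge of the scatter. The expected step is a number 10 percentage points lower from compound 2 to compound 3 (within the scatter). Compound 3 is estimated at 32%, within a range from 12% to 52%.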

Compound 3, a percentage reported as inhibition, at one concentration (the size of the read-out at that concentration, not a potency): 59%
Compound 3: middle estimate off by 27 percentage points, on the low side, and the stated range ends below it.
By their numbers in this assay, from the lowest: compound 1; then compound 2; then compound 3.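

In this assay, the phenyl ring at the end of this chain proves unnecessary for inhibition at the one concentration tested: putting isopropyl in place of benzyl gives a number 17 percentage points higher from compound 2 to compound 3 (beyond the scatter). The chain can therefore lose its ring and still gain in this read-out, which compound 1 and compound 2 alone could not show. No measurement here explains the rise. Going by these compounds, whether a cyclohexyl group or a straight pentyl chain at this place would behave like isopropyl stays open. So does whether the same change would raise the number on the core of compound 1.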